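Extending the Chain End from Compound 3 to Compound 4

The source may report more compounds than this note shows. Statements on the series, on what has been measured and on what is new or still open speak of the compounds shown alone.

Compound 3 `C/N=C(/NC#N)NCCCCCn1nc(-c2ccccc2)ccc1=O` gives 76.2 mg/kg in a functional assay on the whole organism with Rattus norvegicus as the target (on this read-out higher numbers stand for an effect only at larger amounts of compound and lower numbers for an effect already at smaller amounts), the highest of the two numbers reported. Its nearest neighbour is compound 1 `C/N=C(\S)NCCCCCn1nc(-c2ccccc2)ccc1=O`, which in this assay gives 42.1 mg/kg, and the two lie within the scatter, as a 1.8-fold higher number from compound 1 to compound 3 (0.26 log units; within the scatter) shows. Compound 2 `C/N=C(/NC#N)NCCCCCCn1nc(-c2ccccc2)ccc1=O` is reported in this assay only as a limit, > 100 mg/kg (the limit of > 100 mg/kg in this assay, at which 1 of the 3 values shown sits). The step from compound 3 to compound 4 `CC/N=C(/NC#N)NCCCCCCn1nc(-c2ccccc2)ccc1=O` is a group of 9 heavy atoms (5 carbon, 4 nitrogen; no ring) in place of a group of 7 heavy atoms (3 carbon, 4 nitrogen; no ring), on a saturated chain carbon, five bonds along the chain from an aromatic nitrogen. The measured steps that bear on it are those at the same place in the chain: an at least 2.3-fold higher number from compound 1 to compound 2 (0.37 log units; beyond the scatter) and an at least 1.3-fold lower number from compound 2 to compound 3 (0.11 log units; that floor lies within the scatter), both of which show the larger group going with the higher number, although the growth from compound 1 to compound 3 stayed within the scatter. Relative to compound 3, compound 4 is therefore expected to give a somewhat higher number, a step of roughly a 1.3-fold higher number from compound 3 to compound 4 (0.12 log units; within the scatter), with a real chance that only a limit is reported. Compound 4 is estimated at 100 mg/kg, between 45 mg/kg and 220 mg/kg.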

Compound 4, dose for half-maximal effect: > 100 mg/kg
Compound 4 ended at the assay's limit; the forecaster's own chance of this, stated with the estimate: 45%; the middle value lies on the limit itself.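

Compound 4 is reported in this assay only as a limit, > 100 mg/kg. For the compounds shown here, the larger group at this place on the chain gives an at least 2.3-fold higher number from compound 1 to compound 4 (0.37 log units; beyond the scatter), while an at least 1.3-fold higher number from compound 3 to compound 4 (0.11 log units; that floor lies within the scatter) shows only a floor, so the direction agrees with the earlier steps but its size stays unknown. Methyl in place of hydrogen on a saturated chain carbon bound to a double-bonded nitrogen cannot be read, and the upper end of the series now rests on a ceiling: the limit of > 100 mg/kg in this assay, at which 2 of the 4 values shown sit.

The compounds shown leave open whether any further growth of this group changes the read-out, since every larger group so far ends at or near that limit. They also leave open how a longer chain at this end, or an amine in place of the nitrile, would behave.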